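The source may report more compounds than this note shows. Statements on the series, on what has been measured and on what is new or still open speak of the compounds shown alone.

Three compounds share one core and differ only in where a hydroxy sits or is absent. Compound 1 `C[C@H]1C[C@@H](O)[C@@]23C1=C[C@@]1(C)CC[C@](C)(C[C@H](O)[C@H](O)[C@@](C)(O)CO)[C@H]1[C@@H]2CC[C@@H]3C` carries a hydroxy on a saturated ring carbon that compound 3 `C[C@H]1CC[C@@]23C1=C[C@@]1(C)CC[C@](C)(C[C@H](O)[C@H](O)[C@@](C)(O)CO)[C@H]1[C@@H]2CC[C@@H]3C` lacks, and compound 2 `C[C@H]1CC[C@@]23C1=C[C@@]1(C)CC[C@](C)(C[C@H](O)[C@H](O)[C@@](C)(O)CO)[C@H]1[C@@H]2C[C@@H](O)[C@@H]3C` carries one on a different saturated ring carbon that compound 3 also lacks. In a functional assay on cells (Panel NCI-60 (60 carcinoma cell lines), Homo sapiens) for inhibition (a higher number here means a weaker inhibitor, a lower number a stronger inhibitor), compound 1 gives 18000 nM, compound 2 gives 18000 nM, and compound 3 gives 18000 nM. The step of no change at the digits printed from compound 1 to compound 3 (within the scatter) and the step of no change at the digits printed from compound 2 to compound 3 (within the scatter) both show that removing a ring hydroxy left the result where it was, so compound 3 stands level with compounds 1 and 2.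

Compound 4 `C[C@H]1CC[C@@]23C1=C[C@@]1(C)CC[C@](C)(C[C@H](O)[C@H](O)C(C)(C)O)[C@H]1[C@@H]2CC[C@@H]3C` is compound 3 with one more hydroxy taken away, this time on the side chain: hydrogen in place of hydroxy on a saturated chain carbon, two bonds along the chain from an oxygen on a saturated carbon. Both measured steps bear on this change only loosely, since they concern ring carbons rather than the chain, yet each was flat. The step from compound 3 to compound 4 is therefore expected to be no change at the digits printed from compound 3 to compound 4 (within the scatter), with nothing beyond the scatter. Compound 4 is estimated at 18000 nM in this assay, within a range from 9000 nM to 40000 nM.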

Compound 4, half-maximal inhibitory concentration: 18000 nM
Beside the measured number, compound 4's estimate shows no gap at the digits printed; the measured number falls inside the stated range.
By their numbers in this assay, from the lowest: compounds 1, 2, 3 and 4 (each within the scatter of the next).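

The earlier steps shown here touched only ring carbons, whereas here the side chain itself changes: in this assay the change from 1-hydroxy-1-(hydroxymethyl)ethyl to 1-hydroxy-1-methylethyl gives no change at the digits printed from compound 3 to compound 4 (within the scatter) and so extends the flat picture from the ring to this chain position. Within these four compounds, none of the three hydroxy groups removed in these steps shifts the result beyond the scatter, and none of the compounds goes against this. The compounds shown leave open whether a different group at this chain carbon, such as an amine or a carboxylic acid, or a longer chain there would move the number. They also leave open what the hydroxy groups still on the side chain of compound 4 contribute. No supporting measurement is available to explain this flat result.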